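A few compounds are considered here, and "the series" means these few. Any claim that something is new, unique, unknown or untested is made for them only; others in the source may bear on it.

In an assay on cells for displacement of a labelled ligand from transmembrane domain-containing protein TMIGD3 (Homo sapiens), read by scintillation counting, with a stated time of 120 min, tested at 1 uM (a higher number here means more inhibition at the concentration tested (going by the name of the read-out), a lower number less inhibition), compound 1 `Nc1nccn2cc(-c3ccccc3)nc12` gives 12%. Compound 2 `COc1cccc(-c2cn3cc(-c4ccccc4)nc3c(N)n2)c1` gives 21%, and compound 3 `COc1ccc(-c2cn3cc(-c4ccccc4)nc3c(N)n2)cc1` gives 23%, the highest of the three numbers, although its gap to compound 2 lies within the scatter and only a number 11 percentage points higher from compound 1 to compound 3 (beyond the scatter) stands beyond it. The remaining steps, a number 9 percentage points higher from compound 1 to compound 2 (within the scatter) and a number 2 percentage points higher from compound 2 to compound 3 (within the scatter), round out what has been measured. Compound 4 `Nc1nc(-c2ccc(OCc3ccccc3)cc2)cn2cc(-c3ccccc3)nc12` differs from compound 3 by phenyl in place of hydrogen on a saturated chain carbon bound to an oxygen on an aromatic ring. Among the measured compounds shown here, none of the measured steps touches this change, since each of them alters what sits on the shared core rather than the methoxy group, so no step beyond the scatter is expected. In this assay compound 4 is therefore estimated to give 27%, between 10% and 45%. That estimate corresponds to an expected step of a number 4 percentage points higher from compound 3 to compound 4 (within the scatter).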

Compound 4, a percentage reported as inhibition, at one concentration (the size of the read-out at that concentration, not a potency): 1%
Estimate against measurement, compound 4: 26 percentage points above, and the stated range ends above it.
By their numbers in this assay, from the lowest: compound 4; then compounds 1, 2 and 3 (each within the scatter of the next, the first and the last beyond it).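

The earlier steps shown here changed only what sits on the shared core, whereas this one extends the methoxy group itself to benzyloxy, and in this assay the result is a number 22 percentage points lower from compound 3 to compound 4 (beyond the scatter). The saturated chain carbon bound to an oxygen on an aromatic ring is therefore not indifferent to what is added there, and a phenyl on it costs inhibition at the concentration tested. Nothing measured here gives a cause for this fall. The compounds shown leave open whether a methyl on that carbon, as in an ethoxy group, would already lower the number, or whether a hydroxy group in place of methoxy would change it.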